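Dichloroacetanilides on Bel-7402 cells: halogen swap note

This account rests on a few compounds, and the source may have more. Where it says the series, first, only, none or still open, it means among the compounds named here.

Measured compounds:
- compound 1 `O=C(Nc1ccccc1)C(Cl)Cl`, a functional assay on Bel-7402 cells (Homo sapiens) for antiproliferative activity, read by MTT assay, with a stated time of 72 h; a higher number here means a weaker inhibitor, a lower number a stronger inhibitor: "not determined" (no result reported)
- compound 2 `O=C(Nc1ccccc1Br)C(Cl)Cl`, this assay: 38200 nM
- compound 3 `O=C(Nc1cccc(F)c1)C(Cl)Cl`, this assay: "not determined" (no result reported)

Compound 3 stands without a number in this assay, and compound 1 is in the same position; the only half-maximal inhibitory concentration in the set belongs to compound 2 at 38200 nM, which is a weak result. For the measured compounds named here, no step between measured compounds can be drawn from these three entries.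

Compound 4 `O=C(Nc1cccc(I)c1)C(Cl)Cl` is the next member. It differs from compound 3 in one place: iodo in place of fluoro on an aromatic carbon. Going by the values given here, as compound 3 carries no value, no step can be stated for this change, and the size of its effect in this assay is unknown. Among the compounds with values here, the one number available, from compound 2, places the series in a weak range, so a weak result is the working expectation for compound 4 as well, with wide uncertainty in both directions.

Compound 4 is estimated at 30000 nM in this assay, with a range from 8000 nM to 100000 nM.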

Compound 4, half-maximal inhibitory concentration: 5390 nM
Beside the measured number, compound 4's estimate is 5.6-fold (0.75 log units) above it, and the stated range ends above it.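

For the compounds shown here, with compound 3 holding no single number in this assay, no step to compound 4 can be read. The compounds shown leave open how iodo compares with fluoro at this place on the shared core. No measured evidence at hand bears on this result.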